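The source may report more compounds than this note shows. Statements on the series, on what has been measured and on what is new or still open speak of the compounds shown alone.

Of the compounds shown here, three sharing one core have been tested in an ADME assay on HeLa cells (Homo sapiens) for cytotoxicity, read by MTT assay; a lower number here means a stronger inhibitor, a higher number a weaker inhibitor. Compound 1 `COc1ccc(C[C@H]2COC(=O)[C@@H]2Cc2ccc(OCC(=O)Nc3ccccc3)c(OC)c2)cc1OC` gives only a limit in this assay, >= 600000 nM, so its true number is not known and it stands at the edge of what this assay can report. Compound 2 `COc1ccc(C[C@H]2COC(=O)[C@@H]2Cc2ccc(OCC(=O)N3CCCCC3)c(OC)c2)cc1OC` gives 293000 nM in this assay, and compound 3 `COc1ccc(C[C@H]2COC(=O)[C@@H]2Cc2ccc(OCc3cn(Cc4ccccc4Cl)nn3)c(OC)c2)cc1OC` gives 84500 nM. Among the measured compounds shown here, the one step between close neighbours is an at least 2.0-fold lower number from compound 1 to compound 2 (0.31 log units; beyond the scatter); this step is itself only a bound, which follows from the limit of >= 600000 nM in this assay, at which 1 of the 3 values shown sits.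

Compound 4 `COC(=O)CNC(=O)CCC(=O)Oc1ccc(C[C@H]2C(=O)OC[C@@H]2Cc2ccc(OC)c(OC)c2)cc1OC` has not been measured. It differs from compound 1 in that (a group of 12 heavy atoms (7 carbon, 1 nitrogen, 4 oxygen; no ring) in place of a group of 10 heavy atoms (8 carbon, 1 nitrogen, 1 oxygen; one six-membered aromatic ring of carbon only), on an oxygen on an aromatic ring). For the measured compounds named here, no measured step swaps the (phenylcarbamoyl)methyl for an open chain of this kind, so the step from compound 1 to compound 2 is the nearest guide, and it tells only that removing the anilino part lowered the number by a bound. In this assay compound 4 is therefore expected to remain a weak inhibitor, with an expected step of an at least 1.3-fold lower number from compound 1 to compound 4 (0.12 log units; that floor lies within the scatter) that need not go beyond the scatter. The estimate for compound 4 in this assay is 450000 nM, with a range from 120000 nM to 1500000 nM.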

Compound 4, half-maximal inhibitory concentration: 179000 nM
The estimate for compound 4 lay 2.5-fold (0.40 log units) above the measured number, within the range that was stated.
By their numbers in this assay, from the lowest: compound 3; then compounds 4 and 2 (each within the scatter of the next). At a limit, above all of these: compound 1.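

In this assay, the open chain of compound 4 is a second replacement for the (phenylcarbamoyl)methyl on this oxygen on an aromatic ring, and it shows that a group with no ring at all also gives a clear step: an at least 3.3-fold lower number from compound 1 to compound 4 (0.52 log units; beyond the scatter). Among the compounds shown here, until now the only such step came from a group that still held a ring, whereas this one also brings more hydrogen-bond acceptors and more double bonds outside aromatic rings, so keeping a ring in this group is not required for a number under the limit of compound 1. Two very different groups also end up close together, with a 1.6-fold lower number from compound 2 to compound 4 (0.21 log units; within the scatter), and the size of the step from compound 1 stays a bound, as compound 1 gives only a limit: the limit of >= 600000 nM in this assay, at which 1 of the 4 values shown sits.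

The compounds shown leave open which part of the open chain matters, as the chain differs from the groups it replaces in several features at once, and a shorter open chain, a longer chain or one ending in a carboxylic acid would help to separate them. They also leave open how a simple amine at the end of such a chain would read in this assay.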